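Cyclopropyl in place of butyl on the aromatic nitrogen

This account rests on a few compounds, and the source may have more. Where it says the series, first, only, none or still open, it means among the compounds named here.

In an ADME assay on C8166 cells (Homo sapiens) for cytotoxicity, read by MTT assay (on this read-out lower numbers stand for higher toxicity in this test and higher numbers for lower toxicity in this test), compound 1 (`CCCCn1cc(C(=O)O)c(=O)c2c(O)c(Cc3cccc(Cl)c3F)ccc21`) gives 20000 nM and stands level with the two other measured compounds. Compound 2 (`CCCCCn1cc(C(=O)O)c(=O)c2c(O)c(Cc3cccc(Cl)c3F)ccc21`) gives 39900 nM and compound 3 (`CCC(C)n1cc(C(=O)O)c(=O)c2c(O)c(Cc3cccc(Cl)c3F)ccc21`) gives 30700 nM on the same read-out, so no gap among the three exceeds the scatter.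

Compound 4 (`O=C(O)c1cn(C2CC2)c2ccc(Cc3cccc(Cl)c3F)c(O)c2c1=O`) is still unmeasured and differs from compound 1 by cyclopropyl in place of butyl on an aromatic nitrogen. Going by the values given here, the steps that bear on it all alter the same substituent: a 2.0-fold higher number from compound 1 to compound 2 (0.30 log units; within the scatter) and a 1.5-fold higher number from compound 1 to compound 3 (0.19 log units; within the scatter) and a 1.3-fold lower number from compound 2 to compound 3 (0.11 log units; within the scatter) all stay within the scatter. Among the compounds with values here, no measured compound carries a ring on that nitrogen, so the change goes beyond what has been tested. Within the data shown here, with those three steps as the only guide, no step beyond the scatter is expected in this assay for this change. The estimated step is a 1.3-fold higher number from compound 1 to compound 4 (0.10 log units; within the scatter) and would stay within the scatter. For compound 4 the expected value is 25000 nM with an estimated range of 11000 nM to 55000 nM in this test.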

Compound 4, half-maximal cytotoxic concentration: 39100 nM
Compound 4: middle estimate off by 1.6-fold (0.19 log units), on the low side, and the stated range covers the measured number.
By their numbers in this assay, from the lowest: compounds 1, 3, 4 and 2 (each within the scatter of the next).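

In this assay, the series now includes a ring on the aromatic nitrogen, and cyclopropyl stays within the scatter of all three open-chain groups: in place of butyl (a 2.0-fold higher number from compound 1 to compound 4 (0.29 log units; within the scatter)), sec-butyl (a 1.3-fold higher number from compound 3 to compound 4 (0.11 log units; within the scatter)) and pentyl (a 1.0-fold lower number from compound 2 to compound 4 (0.01 log units; within the scatter)). Across these four compounds, neither swapping an open chain for the three-membered ring nor changing the chain itself gives a step beyond the scatter on this read-out. No supporting evidence bears on this result.

On these data alone, it remains open whether the number would also stay level with a phenyl ring, a cyclohexyl ring or a chain longer than pentyl on that nitrogen. A chain ending in an amine or a hydroxyl group at the same place is likewise untested among the compounds shown.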